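The source may hold more compounds than are shown below. What is called first, only, known or untested is meant among the compounds shown, and "the series" means these compounds.

Compound 3 `COc1ccc2[nH]c3c(c2c1)CCNC31CCN(Cc2cc(F)c(F)cc2F)CC1` gives 600 nM in an assay on FRT cells for positive allosteric modulation of Cystic fibrosis transmembrane conductance regulator variant N1303K (Homo sapiens), in the presence of a further agent that is not named here (on this read-out lower numbers stand for an effect already at smaller amounts and higher numbers for an effect only at larger amounts of compound), and so holds the lowest of the three numbers recorded here. Compound 1 `COc1ccc2[nH]c3c(c2c1)CCNC31CCN(Cc2c(F)ccc(Cl)c2F)CC1` gives 1500 nM in this assay, and compound 2 `COc1ccc2[nH]c3c(c2c1)CCNC31CCN(Cc2cc(F)cc(F)c2)CC1` gives 11100 nM in this assay. Compound 4 `COc1ccc2[nH]c3c(c2c1)CCNC31CCN(Cc2cccnc2)CC1` has not yet been measured; it differs from compound 3 by pyridin-3-yl in place of 2,4,5-trifluorophenyl on a saturated chain carbon bound to an amine nitrogen in a ring. All three measured steps concern an exchange of the aromatic ring at this same place, and each moved the number beyond the scatter: a 2.5-fold lower number from compound 1 to compound 3 (0.40 log units; beyond the scatter), a 7.4-fold higher number from compound 1 to compound 2 (0.87 log units; beyond the scatter) and a 19-fold lower number from compound 2 to compound 3 (1.27 log units; beyond the scatter). None of them removes every fluorine or brings in a ring nitrogen, so the present change reaches further than any of those. The ring with the fewest halogens among the measured compounds, in compound 2, gave 11100 nM, the highest number of the set. A higher number is therefore expected for compound 4 in this assay, namely a 10-fold higher number from compound 3 to compound 4 (1.00 log units; beyond the scatter). Compound 4 is estimated at 6000 nM in this assay, within a range from 1500 nM to 25000 nM.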

Compound 4, half-maximal effective concentration: 17000 nM
Beside the measured number, compound 4's estimate is 2.8-fold (0.45 log units) below it, and the stated range covers the measured number.
By their numbers in this assay, from the lowest: compound 3; then compound 1; then compounds 2 and 4 (each within the scatter of the next).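

In this assay, the halogen-free pyridin-3-yl ring does not separate from the 3,5-difluorophenyl ring, with a 1.5-fold higher number from compound 2 to compound 4 (0.19 log units; within the scatter), whereas the other two rings stand clearly apart from it, with a 28-fold higher number from compound 3 to compound 4 (1.45 log units; beyond the scatter) and an 11-fold higher number from compound 1 to compound 4 (1.05 log units; beyond the scatter). At this position, then, removing every fluorine and bringing in a ring nitrogen gives a number that cannot be told from that of compound 2, which still carries two fluorines, so the presence of fluorine alone does not set compound 3 and compound 1 apart from compound 4. Nothing available here explains this result.

The compounds shown leave open whether a plain phenyl ring would read like compound 4, which would separate the effect of the ring nitrogen from that of losing the fluorines. They also leave open whether a fluoropyridin-3-yl ring would come closer to compound 3 or to compound 4.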